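Thiazolyl in Place of Hydroxy on the Shared Core

The source may hold more compounds than are shown below. What is called first, only, known or untested is meant among the compounds shown, and "the series" means these compounds.

Within the data shown here, compound 2 `O=C1NCCN(c2cccc(O)c2)N1` gives 32000 nM in an assay on RBL-1 cells for inhibition of Polyunsaturated fatty acid 5-lipoxygenase (Rattus norvegicus) (on this read-out higher numbers stand for weaker inhibition and lower numbers for stronger inhibition), the highest of the two numbers known so far. Compound 1 `O=C1NCCN(c2cccc(OCc3ccccc3)c2)N1` gives 1100 nM, and the step of a 29-fold higher number from compound 1 to compound 2 (1.46 log units; beyond the scatter) is large. Compound 3 `O=C1NCCN(c2cccc(-c3nccs3)c2)N1` differs from compound 2 by 1,3-thiazol-2-yl in place of hydroxy on an aromatic carbon. Among the measured compounds shown here, no measured step matches this change directly; the only guidance is that stripping the benzyl from compound 1 to compound 2 went with a much higher number, so a larger group on that carbon again may bring the number down. Compound 3 is therefore expected to show a lower number, a step of an 8.0-fold lower number from compound 2 to compound 3 (0.90 log units; beyond the scatter), with an estimate of 4000 nM between 800 nM and 20000 nM.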

Compound 3, half-maximal inhibitory concentration: 35000 nM
Beside the measured number, compound 3's estimate is 8.8-fold (0.94 log units) below it, outside the stated range (above it).
By their numbers in this assay, from the lowest: compound 1; then compounds 2 and 3 (each within the scatter of the next).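

In this assay, the change appears as a 1.1-fold higher number from compound 2 to compound 3 (0.04 log units; within the scatter), so 1,3-thiazol-2-yl and hydroxy on this aromatic carbon cannot be told apart, and a larger group here does not by itself go with a lower number. Among the compounds shown, only compound 1 , at 1100 nM, goes against this reading. No available measurement explains the result. Going by these compounds, it remains open whether an amine or a carboxylic acid on this carbon, or a longer chain on the oxygen, would track with compound 1 or with compound 3.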